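Halogen Swap on the Pendant Aryl Ring: Estimating Compound 4

A few compounds are considered here, and "the series" means these few. Any claim that something is new, unique, unknown or untested is made for them only; others in the source may bear on it.

Compound 1, `Oc1ccccc1/C=N/c1nnc(SCc2nnc(-c3ccccc3)o2)s1`: 7100 nM
Compound 2, `Oc1ccccc1/C=N/c1nnc(SCc2nnc(-c3ccc(F)cc3)o2)s1`: 13100 nM
Compound 3, `Oc1ccccc1/C=N/c1nnc(SCc2nnc(-c3ccc(Cl)cc3)o2)s1`: 2840 nM

Of the compounds shown here, three sharing one core have been tested in a functional assay on SMMC-7721 cells (Homo sapiens) for inhibition, read by CCK-8 assay; a lower number here means a stronger inhibitor, a higher number a weaker inhibitor. Compound 1 gives 7100 nM, compound 2 gives 13100 nM, and compound 3 gives 2840 nM, which is the lowest of the three numbers. The steps among them are modest: a 2.5-fold lower number from compound 1 to compound 3 (0.40 log units; beyond the scatter) and a 4.6-fold lower number from compound 2 to compound 3 (0.66 log units; beyond the scatter), whereas a 1.8-fold higher number from compound 1 to compound 2 (0.27 log units; within the scatter).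

Compound 4, `Oc1ccccc1/C=N/c1nnc(SCc2nnc(-c3ccccc3Br)o2)s1`, has not yet been measured in this assay. It differs from compound 3 in one place: 2-bromophenyl in place of 4-chlorophenyl on an aromatic carbon. For the measured compounds named here, none of the measured steps involves bromine, and none moves the halogen from the place it holds in 4-chlorophenyl to the place it holds in 2-bromophenyl; the steps that bear on this change are only the ones in which chloro replaced hydrogen or fluoro, and both were modest. Going by the values given here, because the gain seen in a 2.5-fold lower number from compound 1 to compound 3 (0.40 log units; beyond the scatter) has no direct counterpart here, compound 4 is expected to land near compound 3 or somewhat higher. The step of a 1.4-fold higher number from compound 3 to compound 4 (0.15 log units; within the scatter) is therefore expected to be small. The estimate for compound 4 in this assay is 4000 nM, with a range from 1500 nM to 12000 nM.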

Compound 4, half-maximal inhibitory concentration: 6780 nM
Beside the measured number, compound 4's estimate is 1.7-fold (0.23 log units) below it; the measured number falls inside the stated range.
By their numbers in this assay, from the lowest: compound 3; then compounds 4, 1 and 2 (each within the scatter of the next).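

In this assay, 2-bromophenyl in place of 4-chlorophenyl gives a 2.4-fold higher number from compound 3 to compound 4 (0.38 log units; beyond the scatter) and so does not keep the low number of compound 3, which shows that a halogen on this phenyl ring does not by itself carry the gain; this one change alters both the halogen and where it sits. Bromo in place of hydrogen gives a 1.0-fold lower number from compound 1 to compound 4 (0.02 log units; within the scatter) and 2-bromophenyl in place of 4-fluorophenyl gives a 1.9-fold lower number from compound 2 to compound 4 (0.29 log units; within the scatter), both within the scatter, so compound 4 cannot be told apart from compound 1 or compound 2, and compound 3 alone stands apart from the other three as the strongest inhibitor of the set. Nothing available explains this result.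

The compounds shown leave open whether the halogen or its place on the ring matters more, as none carries bromine where 4-chlorophenyl holds its chlorine or chlorine where 2-bromophenyl holds its bromine. Also open, going by these compounds, is how this ring would respond to a group other than a halogen, such as an amine or a carboxylic acid.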